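Cyano in place of methoxy: notes toward compound 3

The compounds below may be only part of what the source reports. "The series", "measured", "known", "first", "only" and "open" are said of these compounds alone.

Two compounds of this series stand measured in an assay on HEK293 cells for inhibition of sodium channel protein type 3 subunit alpha (Homo sapiens), read by electrophysiology, with a stated time of 3.5 min; on this read-out higher numbers stand for weaker inhibition and lower numbers for stronger inhibition. Compound 1 `NC(=O)CN1CCCc2cc(OCc3ccccc3F)ccc2C1` reaches only a limit of the assay, > 79400 nM, so no number is known for it. Among the measured compounds shown here, compound 2 `COc1cc([C@H]2CC[C@@H](C(N)=O)N2)ccc1OCc1ccccc1F` gives 63100 nM in this assay, and this is the only number in the set so far. The remainder of the set sits at the limit of > 79400 nM in this assay, at which 1 of the 2 values shown sits. Compound 2 therefore stands as the one reference point with a measured inhibitory concentration, weak as it is.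

Compound 3 `N#Cc1cc([C@H]2CC[C@@H](C(N)=O)N2)ccc1OCc1ccccc1F` differs from compound 2 by cyano in place of methoxy on an aromatic carbon. For the measured compounds named here, no step between measured compounds covers a change of this kind, so there is no measured guide for its size or direction. The expectation is a step of a 1.1-fold lower number from compound 2 to compound 3 (0.06 log units; within the scatter) that stays within the usual scatter, with no clear direction. On that basis compound 3 is estimated at 55000 nM in this assay, in a range from 15000 nM to 160000 nM, with a real chance that only a limit is reported.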

Compound 3, half-maximal inhibitory concentration: > 50100 nM
Compound 3 gave a limit, no number; the forecaster's own chance of this, stated with the estimate: 40%; the middle value is on the limit's open side.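

Compound 3 gives only a limit, > 50100 nM, and not a number. Among the compounds shown here, no step from compound 2 to compound 3 can be read, so this pair gives no size for the exchange of methoxy for cyano. The compounds shown leave open whether that exchange on an aromatic carbon changes the inhibitory concentration at all, and in which direction.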